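Swapping methoxy for chloro on a diaryl urea

The compounds below may be only part of what the source reports. "The series", "measured", "known", "first", "only" and "open" are said of these compounds alone.

Measured so far:
- compound 1, `Cc1cccc(NC(=O)N[C@@H](C)c2ccccc2)c1`: 100%
- compound 2, `CC(C)c1cccc(NC(=O)N[C@@H](C)c2ccccc2)c1`: 86%
- compound 3, `COc1cccc(NC(=O)N[C@@H](C)c2ccccc2)c1`: 99%

All three were tested in an ADME assay on the whole organism with Oryza sativa as the target, tested at 10 uM; a higher number here means a weaker effect of the compound at the concentration tested, a lower number a stronger effect. Compound 3 stands second highest of the three numbers. Its nearest neighbour is compound 1, and that pair differs only a number 1 percentage points lower from compound 1 to compound 3 (within the scatter), a gap within the scatter. Compound 2 is the furthest: a number 13 percentage points higher from compound 2 to compound 3 (beyond the scatter).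

The next compound is compound 4, `C[C@H](NC(=O)Nc1cccc(Cl)c1)c1ccccc1`. It differs from compound 3 in one place: chloro in place of methoxy on an aromatic carbon.

For the measured compounds named here, no measured step exchanges methoxy for chloro, so none bears directly on it. What the measured steps do show is that methyl and methoxy give nearly the same number, a number 1 percentage points lower from compound 1 to compound 3 (within the scatter), while the larger isopropyl lowers it modestly, a number 14 percentage points lower from compound 1 to compound 2 (beyond the scatter). Chloro is a single heavy atom, closer in size to methyl than to isopropyl, so the step is expected to be small, a number 4 percentage points lower from compound 3 to compound 4 (within the scatter), within the scatter.

Compound 4 is therefore estimated at 95%, between 80% and 100%.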

Compound 4, a percentage reported as activity, at one concentration (the size of the read-out at that concentration, not a potency): 103%
Compound 4: the middle estimate sits 8 percentage points below what was measured; the whole stated range lies below it.
By their numbers in this assay, from the lowest: compound 2; then compounds 3, 1 and 4 (each within the scatter of the next).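

In this assay, chloro at this position, on an aromatic carbon meta to a large group, cannot be told apart from methoxy, with a number 4 percentage points higher from compound 3 to compound 4 (within the scatter), or from methyl, with a number 3 percentage points higher from compound 1 to compound 4 (within the scatter). Methoxy carries a hydrogen-bond acceptor and chloro has none, yet that exchange gives no readable change here, and compound 2 is the one that stands apart from the other three, with a number 17 percentage points higher from compound 2 to compound 4 (beyond the scatter). No measurement shown gives a reason for this pattern.

On these data alone, whether a tert-butyl group, an amine or a carboxylic acid on this carbon would group with isopropyl or with the other three remains open. As far as these compounds go, the rest of the core is the same in all four compounds, so it is also open whether the pattern would hold with a change elsewhere.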